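The source may report more compounds than this note shows. Statements on the series, on what has been measured and on what is new or still open speak of the compounds shown alone.

Measured in a functional assay on P388 cells (Mus musculus) for inhibition; on this read-out lower numbers stand for stronger inhibition and higher numbers for weaker inhibition:

- Compound 1 `C(=C\c1ccco1)\c1ccc2ccccc2c1`: > 5000 nM
- Compound 2 `C(=C/c1ccc2ccccc2c1)\c1ccoc1`: > 5000 nM

Neither entry is an exact number. Each one is a limit of the assay, and the shared position is the limit of > 5000 nM in this assay, at which 2 of the 2 values shown sit. Compound 2 therefore stands at > 5000 nM, which is a limit, so no exact strength can be read from it.

The next compound is compound 3 `C(=C\c1ccc2ccccc2c1)\c1ccoc1`. The change is the two compounds have the same atoms and bonds and differ only in configuration as drawn: 1 of 1 stereo elements differ; a double bond is drawn E in compound 2 and Z in compound 3. Among the compounds with values here, no measured pair here shows what such a change does in this assay, so the only guide is the limit reached by compound 2. A step beyond the usual scatter is not expected, and no clear direction can be predicted. The expected step is a step that the limit leaves unreadable from compound 2 to compound 3. For compound 3 the estimated value is 6000 nM. The expected range for compound 3 runs from 2000 nM to 20000 nM.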

Compound 3, half-maximal inhibitory concentration: > 5000 nM
Compound 3: only a limit was reported (the forecaster's own chance of this, stated with the estimate: 75%); the middle value is on the limit's open side.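

Compound 3 also gives only a limit, so no step from compound 1 or compound 2 to compound 3 can be read: the limit of > 5000 nM in this assay, at which 3 of the 3 values shown sit.

The compounds shown leave open how strongly any of the three inhibits, and whether furan-3-yl in place of furan-2-yl, or an E or Z double bond, changes that at all.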